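Working notes on the step from compound 2 to compound 3

A few compounds are considered here, and "the series" means these few. Any claim that something is new, unique, unknown or untested is made for them only; others in the source may bear on it.

Going by the values given here, compound 2 `Cc1c(/N=C/c2ccc(Cl)cc2Cl)c(=O)n(-c2ccccc2)n1C` gives 269000000 nM in a functional assay on HCT-116 cells (Homo sapiens) for cytotoxicity, read by MTT assay, with a stated time of 72 h (a lower number here means a stronger inhibitor, a higher number a weaker inhibitor), the lowest of the two numbers so far. Compound 1 `Cc1c(/N=C/c2cccc(O)c2)c(=O)n(-c2ccccc2)n1C` gives 617000000 nM in this assay, and the step of a 2.3-fold lower number from compound 1 to compound 2 (0.36 log units; beyond the scatter) came with 2,4-dichlorophenyl in place of 3-hydroxyphenyl on a carbon with a double bond to nitrogen. Compound 3 `Cc1c(/N=C/c2cccc(Cl)c2)c(=O)n(-c2ccccc2)n1C` differs from compound 2 by 3-chlorophenyl in place of 2,4-dichlorophenyl on a carbon with a double bond to nitrogen. Among the compounds with values here, no measured step covers this exact change; the single step seen, a 2.3-fold lower number from compound 1 to compound 2 (0.36 log units; beyond the scatter), involves other groups at the same carbon and was modest, so a step within the scatter or a modest rise is expected. Compound 3 is expected at 400000000 nM (range 200000000 nM to 800000000 nM), meaning an expected 1.5-fold higher number from compound 2 to compound 3 (0.17 log units; within the scatter).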

Compound 3, half-maximal inhibitory concentration: 912000000 nM
Beside the measured number, compound 3's estimate is 2.3-fold (0.36 log units) below it; the whole stated range lies below it.
By their numbers in this assay, from the lowest: compound 2; then compounds 1 and 3 (each within the scatter of the next).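

In this assay, 3-chlorophenyl in place of 2,4-dichlorophenyl on a carbon with a double bond to nitrogen gives a 3.4-fold higher number from compound 2 to compound 3 (0.53 log units; beyond the scatter) and so, of the three compounds, only compound 2 stands apart, with its steps to both others beyond the scatter. Chloro in place of hydroxy on an aromatic carbon gives a 1.5-fold higher number from compound 1 to compound 3 (0.17 log units; within the scatter) and so does not separate compound 1 from compound 3. No evidence here explains either step.

As far as these compounds go, whether an amine or a carboxylic acid in place of the chloro of compound 3 would shift the number stays open. So does whether any change to the shared core would do so.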